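Swapping Ethylamino for Dimethylamino on the Side Chain

A few compounds are considered here, and "the series" means these few. Any claim that something is new, unique, unknown or untested is made for them only; others in the source may bear on it.

- compound 1 `C=C(c1ccc2c(c1)C=CC(C)(C)O2)c1ccc(OC)cc1NC(=O)CNC`: 320 nM
- compound 2 `C=C(c1ccc2c(c1)C=CC(C)(C)O2)c1ccc(OC)cc1NC(=O)CNCC`: 1870 nM

For the measured compounds named here, in a functional assay on A2780 cells (Homo sapiens) for antiproliferative activity, read by MTT assay, with a stated time of 48 h (a higher number here means a weaker inhibitor, a lower number a stronger inhibitor), compound 2 gives 1870 nM, the higher of the two numbers so far, and its only neighbour, compound 1, gives 320 nM. The next compound, compound 3 `C=C(c1ccc2c(c1)C=CC(C)(C)O2)c1ccc(OC)cc1NC(=O)CN(C)C`, has the same atoms as compound 2, joined differently: dimethylamino in place of ethylamino on a saturated chain carbon bound to a carbonyl carbon. In words, this is dimethylamino in place of ethylamino on a saturated chain carbon bound to a carbonyl carbon.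

Going by the values given here, only one measured step bears on this change: a 5.8-fold higher number from compound 1 to compound 2 (0.77 log units; beyond the scatter). This modest step, beyond the scatter, came with methyl in place of hydrogen on a saturated chain carbon bound to an amine nitrogen. Among the compounds with values here, it shows that the number in this assay can respond to a small edit at this amine, but no measured compound carries dimethylamino, so the direction remains tentative. A partial return towards lower numbers is expected, smaller than that measured step. The expected size is an estimated 2.5-fold lower number from compound 2 to compound 3 (0.40 log units; beyond the scatter). For compound 3 the estimated value is 750 nM, with an expected range from 220 nM to 2500 nM.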

Compound 3, half-maximal inhibitory concentration: 510 nM
Estimate against measurement, compound 3: 1.5-fold (0.17 log units) above, within the range that was stated.
By their numbers in this assay, from the lowest: compounds 1 and 3 (each within the scatter of the next); then compound 2.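

In this assay, rearranging the same 3 heavy atoms gave a 3.7-fold lower number from compound 2 to compound 3 (0.56 log units; beyond the scatter), so the higher number of compound 2 goes with ethylamino as a particular arrangement and not with the atom count of the group on the saturated chain carbon bound to a carbonyl carbon. Placing a methyl on the amine nitrogen gave a 1.6-fold higher number from compound 1 to compound 3 (0.20 log units; within the scatter), whereas placing one on the saturated chain carbon bound to an amine nitrogen gave a 5.8-fold higher number from compound 1 to compound 2 (0.77 log units; beyond the scatter); among these compounds, the same added methyl is therefore beyond the scatter in one place and within it in the other. No measurement shown here accounts for this difference between ethylamino and dimethylamino.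

The compounds shown leave open how far this holds for other groups in the same place, such as an unsubstituted amino group, diethylamino or a pyrrolidine ring, any of which would show whether a larger group on the nitrogen raises the number again. Going by these compounds, it also remains open whether the order seen here would hold on a core other than the shared one, or in a different cell line.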